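A few compounds are considered here, and "the series" means these few. Any claim that something is new, unique, unknown or untested is made for them only; others in the source may bear on it.

Measured so far in a functional assay on HCT-116 cells (Homo sapiens) for cytotoxicity, read by MTT assay, with a stated time of 72 h; a lower number here means a stronger inhibitor, a higher number a weaker inhibitor:
- compound 1, `NS(=O)(=O)c1cc(-c2nnc(CN3CCN(c4ccc(Cl)cc4)CC3)o2)c(Cl)cc1SCc1ccccc1`: 78000 nM
- compound 2, `NS(=O)(=O)c1cc(-c2nnc(Cn3cc(-c4ccccc4)nn3)o2)c(Cl)cc1SCc1ccccc1`: 75000 nM

Compound 2 and compound 1 sit within the scatter of each other; neither can be called the stronger inhibitor, and both are weak in this assay. Compound 3, `NS(=O)(=O)c1cc(-c2nnc(/C=C/c3c(Cl)cccc3Cl)o2)c(Cl)cc1SCc1ccccc1`, differs from compound 2 in one place: 2-(2,6-dichlorophenyl)ethenyl in place of (4-phenyl-1H-1,2,3-triazol-1-yl)methyl on an aromatic carbon. Going by the values given here, no measured pair shows what this exchange does. With only two weak, near-identical numbers to lean on, the expectation for compound 3 is a step of a 1.4-fold lower number from compound 2 to compound 3 (0.13 log units; within the scatter), not beyond the scatter, with wide uncertainty. Compound 3 is estimated at 55000 nM, between 15000 nM and 150000 nM.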

Compound 3, half-maximal inhibitory concentration: 32000 nM
Beside the measured number, compound 3's estimate is 1.7-fold (0.24 log units) above it, and the stated range covers the measured number.
By their numbers in this assay, from the lowest: compound 3; then compounds 2 and 1 (each within the scatter of the next).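

At this position on the five-membered aromatic ring, the substituent can shift the number beyond the scatter in this assay, which the near-identical compound 1 and compound 2 did not show: 2-(2,6-dichlorophenyl)ethenyl in place of (4-phenyl-1H-1,2,3-triazol-1-yl)methyl gives a modest step (a 2.3-fold lower number from compound 2 to compound 3 (0.37 log units; beyond the scatter)). Compound 3 remains a weak inhibitor (32000 nM). No measurement at hand bears on the reason for this step.

Still open, on these data alone, is whether the step follows the ethenyl link or the two chlorine atoms; a plain 2-phenylethenyl or a saturated 2-phenylethyl group here would separate the two.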